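The compounds below may be only part of what the source reports. "The series", "measured", "known", "first", "only" and "open" are said of these compounds alone.

Working notes on the series

Among the measured compounds shown here, compound 1 `O=S(=O)(Nc1ccc2c(-c3ccncc3)c[nH]c2c1)c1ccccc1` and compound 2 `Cn1cc(C#N)c2ccc(NC(=O)NOCc3ccccc3)cc21` share no single-point relation, so no step between them can be computed; only their two numbers can be set side by side. In a functional assay on PBMC cells (Homo sapiens) for antiproliferative activity (on this read-out lower numbers stand for stronger inhibition and higher numbers for weaker inhibition), compound 1 gives 14000 nM. In this assay compound 2 gives 17000 nM. The two numbers lie within the scatter of each other, so neither compound can be called the weaker or the stronger on this read-out; compound 2 simply carries the upper of the two values, and that gap tells nothing.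

Compound 3 `Cn1cc(C#N)c2ccc(NC(=O)Nc3ccccc3)cc21` is the unmeasured member. It differs from compound 2 in one place: phenyl in place of benzyloxy on an amide-type nitrogen. The urea itself and the core of compound 2 are kept. For the measured compounds named here, no measured pair shows what this exchange does, so the expectation rests on compound 2 alone. The step from compound 2 to compound 3 is expected to be small, on the order of the scatter or a little toward stronger inhibition, giving a 1.4-fold lower number from compound 2 to compound 3 (0.15 log units; within the scatter). Compound 3 is therefore estimated at 12000 nM in this assay, with a range from 4000 nM to 40000 nM.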

Compound 3, half-maximal inhibitory concentration: 14000 nM
The estimate for compound 3 lay 1.2-fold (0.07 log units) below the measured number; measured number inside the range.
By their numbers in this assay, from the lowest: compounds 1, 3 and 2 (each within the scatter of the next).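

Among the compounds shown here, the step at this position, a 1.2-fold lower number from compound 2 to compound 3 (0.08 log units; within the scatter) in this assay, is the first single-point comparison, and it shows that benzyloxy and phenyl on this amide-type nitrogen cannot be told apart on this read-out. The two groups both hold one six-membered aromatic ring of carbon only, while phenyl has fewer heavy atoms and lacks the hydrogen-bond acceptor counted in benzyloxy; even with these differences, compound 2 and compound 3 stay within the scatter of each other. No measured property of either compound bears on this result, so the step stands without an explanation.

As far as these compounds go, whether any other group on this nitrogen, such as an amine, a carboxylic acid or a longer chain in place of phenyl, would give a number clearly apart from those of compound 2 and compound 3 remains open. Also open, from the compounds shown here alone, is what an exchange of the nitrile on the shared core would do, as this step leaves that part of both compounds untouched.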